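Compound 1 to compound 4: 1H-indol-4-yl for 4-methylphenyl

The source may report more compounds than this note shows. Statements on the series, on what has been measured and on what is new or still open speak of the compounds shown alone.

In a physicochemical assay for solubility, read by HPLC, in simulated intestinal fluid, with a stated time of 16 h, tested at 125 ug/mL (on this read-out lower numbers stand for lower solubility and higher numbers for higher solubility), compound 1 `CNC(=O)c1cc(C(=O)NC2CC2)cn(Cc2ccc(C)cc2)c1=O` gives 11 ug/mL, the lowest of the three numbers available. Compound 2 `CNC(=O)c1cc(C(=O)NC2CC2)cn([C@H](C)c2ccccc2)c1=O` gives 815 ug/mL and compound 3 `CNC(=O)c1cc(C(=O)NC2CC2)c(C)n(Cc2ccccc2)c1=O` gives 577 ug/mL. Within the data shown here, compound 3 differs from compound 1 in more than one place, so it offers no clean step. Compound 4 `CNC(=O)c1cc(C(=O)NC2CC2)cn(Cc2cccc3[nH]ccc23)c1=O` has not yet been measured. Its difference from compound 1 is 1H-indol-4-yl in place of 4-methylphenyl on a saturated chain carbon bound to an aromatic nitrogen.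

Among the measured compounds shown here, only one measured step bears on this part of the structure: a 74-fold higher number from compound 1 to compound 2 (1.87 log units; beyond the scatter), with 1-phenylethyl in place of 4-methylbenzyl on an aromatic nitrogen. That large step shows that the number can move with a change here, but it involves a different group, so its size does not carry over. A much smaller upward step is expected in this assay, with the estimate being a 3.2-fold higher number from compound 1 to compound 4 (0.50 log units; beyond the scatter). Compound 4 is estimated at 35 ug/mL, with an expected range of 10 ug/mL to 120 ug/mL.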

Compound 4, solubility: 17 ug/mL
Beside the measured number, compound 4's estimate is 2.1-fold (0.31 log units) above it; the range from low to high includes it.
By their numbers in this assay, from the lowest: compounds 1 and 4 (each within the scatter of the next); then compounds 3 and 2 (each within the scatter of the next).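

In this assay, 1H-indol-4-yl in place of 4-methylphenyl on a saturated chain carbon bound to an aromatic nitrogen gives a 1.5-fold higher number from compound 1 to compound 4 (0.19 log units; within the scatter) and so shows that this position can take a different aromatic group with no change beyond the scatter. The earlier step, a 74-fold higher number from compound 1 to compound 2 (1.87 log units; beyond the scatter) with 1-phenylethyl in place of 4-methylbenzyl, had shown only a large move at this part of the structure. The entering group brings a five-membered aromatic ring with a hetero atom and a hydrogen-bond donor, yet the read-out of compound 4 stays within the scatter of compound 1, and no measurement at hand offers an explanation for this.

Open, from the compounds shown here alone, is how a carboxylic acid or an amine on this aromatic group would read. Also open, going by these compounds, is whether 1H-indol-4-yl combined with the 1-phenylethyl chain would keep the large step seen for compound 2.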